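Chloro for fluoro in a series sitting at the limit

A few compounds are considered here, and "the series" means these few. Any claim that something is new, unique, unknown or untested is made for them only; others in the source may bear on it.

Compound 3 `N#CC1=C(N)Oc2cc3oc(-c4ccccc4)cc(=O)c3c(O)c2C12C(=O)N(Cc1ccccc1)c1ccc(F)cc12` is recorded in a functional assay on NCI-H1299 cells (Homo sapiens) for antiproliferative activity, read by MTT assay, with a stated time of 48 h (a higher number here means a weaker inhibitor, a lower number a stronger inhibitor), only as a limit: compound 3 gives > 50000 nM. Compound 2 `Cc1ccc2c(c1)C1(C(=O)N2Cc2ccccc2)C(C#N)=C(N)Oc2cc3oc(-c4ccccc4)cc(=O)c3c(O)c21` likewise returns a limit, giving > 50000 nM. Compound 1 `CN1C(=O)C2(C(C#N)=C(N)Oc3cc4oc(-c5ccccc5)cc(=O)c4c(O)c32)c2cc(Cl)ccc21` gives 11200 nM. Among the measured compounds shown here, the step from compound 2 to compound 3 a step that the two limits leave unreadable from compound 2 to compound 3 is the only recorded single change, and it cannot be sized because of the limit of > 50000 nM in this assay, at which 2 of the 3 values shown sit. Compound 4 `N#CC1=C(N)Oc2cc3oc(-c4ccccc4)cc(=O)c3c(O)c2C12C(=O)N(Cc1ccccc1)c1ccc(Cl)cc12` differs from compound 3 by chloro in place of fluoro on an aromatic carbon. Compound 1 carries chloro, but its core differs from compound 3 in more than one place, so no measured step sizes this change. Compound 4 is therefore expected to stay close to the limit, estimated at 50000 nM with a range of 15000 nM to 150000 nM. The expected step from compound 3 to compound 4 is a number no higher from compound 3 to compound 4 (the limit leaves the size open), and it is expected to be largely hidden by the limit.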

Compound 4, half-maximal inhibitory concentration: > 50000 nM
Compound 4: a limit, no number (the forecaster's own chance of this, stated with the estimate: 65%); the middle value lies on the limit itself.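

In this assay, chloro on this aromatic carbon leaves compound 4 at a limit, as fluoro does for compound 3 and methyl for compound 2, so the steps among these three cannot be read: the limit of > 50000 nM in this assay, at which 3 of the 4 values shown sit. With chloro on both compounds, phenyl in place of hydrogen on the saturated chain carbon bound to the amide-type nitrogen gives an at least 4.4-fold higher number from compound 1 to compound 4 (0.64 log units; beyond the scatter). The readable change in this pair therefore lies at that carbon, not on the aromatic carbon.

Going by these compounds, whether fluoro, methyl or chloro differ on the aromatic carbon remains open. So does whether an amine or a carboxylic acid there would give a readable value alongside the phenyl group.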